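From compound 2 to compound 3: a side-chain exchange

The source may hold more compounds than are shown below. What is called first, only, known or untested is meant among the compounds shown, and "the series" means these compounds.

Measured so far in an ADME assay for permeability, using PAMPA, with a stated time of 4 h, at pH 7.4; on this read-out higher numbers stand for higher permeability and lower numbers for lower permeability:
- compound 1 `NC(=O)NC/C=C/CN(C[C@H]1Cc2ncccc2CN1)[C@H]1CCCc2cccnc21` gives 2 nm/s
- compound 2 `c1cnc2c(c1)CN[C@@H](CN(CCCCNC1COC1)[C@H]1CCCc3cccnc31)C2` gives 300 nm/s

Compound 2 holds the higher of the two numbers, with compound 1 lying under it by more than the scatter. The unmeasured compound 3 `c1cnc2c(c1)CN[C@@H](CN(CCCC1CCNCC1)[C@H]1CCCc3cccnc31)C2` differs from compound 2 as follows: piperidin-4-yl in place of ((oxetan-3-yl)amino)methyl on a saturated chain carbon, three bonds along the chain from an amine nitrogen. In words, piperidin-4-yl stands in place of ((oxetan-3-yl)amino)methyl on a saturated chain carbon, three bonds along the chain from an amine nitrogen.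

Within the data shown here, one measured step bears on this: a 150-fold higher number from compound 1 to compound 2 (2.18 log units; beyond the scatter). It is large and also exchanges a group on a saturated chain carbon, but the groups differ from those here, so it shows how far this assay can move in this series without fixing a direction. Among the measured compounds shown here, no measured compound carries a piperidin-4-yl group. For the measured compounds named here, with compound 2 at 300 nm/s as the higher of only two numbers, a fall is expected rather than a rise, and the expected step is a 7.5-fold lower number from compound 2 to compound 3 (0.88 log units; beyond the scatter), beyond the scatter. For compound 3 the estimated value is 40 nm/s, with an expected range of 8 nm/s to 200 nm/s.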

Compound 3, apparent permeability: 24 nm/s
Estimate against measurement, compound 3: 1.7-fold (0.22 log units) above; low and high end bracket the measured number.
By their numbers in this assay, from the lowest: compound 1; then compound 3; then compound 2.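

In this assay, the saturated chain carbon three bonds along the chain from an amine nitrogen proves sensitive to the identity of the group even when the heavy-atom count stays equal and both groups carry a non-aromatic ring with one hetero atom: piperidin-4-yl in place of ((oxetan-3-yl)amino)methyl gives a 13-fold lower number from compound 2 to compound 3 (1.10 log units; beyond the scatter). The larger step from the earlier pair is thereby divided, since the piperidin-4-yl side chain still lies well clear of the ring-free side chain of compound 1, with a 12-fold higher number from compound 1 to compound 3 (1.08 log units; beyond the scatter), so both ring-bearing side chains sit above that compound, by different margins. Nothing available accounts for the gap between the two ring-bearing groups.

The exchange alters ring size, the ring oxygen and the hydrogen-bond acceptor count together, and the compounds shown do not separate these changes. A morpholin-4-yl or pyrrolidin-3-yl group, or a dimethylamino group on a longer chain, at this same place would show which of these differences tracks the read-out.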